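The compounds below may be only part of what the source reports. "The series", "measured", "known", "first", "only" and "open" are said of these compounds alone.

Measured compounds in an assay on COS-7 cells for displacement of a labelled ligand from 5-hydroxytryptamine receptor 4 (Homo sapiens), read by scintillation counting, with a stated time of 30 min; on this read-out higher numbers stand for weaker inhibition and lower numbers for stronger inhibition:

- compound 1, `CCOC(=O)N1CCC(CN2CC[C@H](NC(=O)c3cc(Cl)c(N)cc3OC)[C@H](OC)C2)CC1`: 377 nM
- compound 2, `COc1cc(N)c(Cl)cc1C(=O)N[C@H]1CCN(CCCn2cccc2)C[C@H]1OC`: 648 nM
- compound 3, `COc1cc(N)c(Cl)cc1C(=O)N[C@H]1CCN(CCCn2cncn2)C[C@H]1OC`: 1270 nM

Compound 3 gives the highest number of the three. Its nearest neighbour is compound 2, the pair being separated by a 2.0-fold higher number from compound 2 to compound 3 (0.29 log units; within the scatter); its furthest is compound 1, separated by a 3.4-fold higher number from compound 1 to compound 3 (0.53 log units; beyond the scatter), the only gap in the set that exceeds the scatter.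

Compound 4, `COc1cc(N)c(Cl)cc1C(=O)N[C@H]1CCN(CC2CCN(C(=O)N(C)C)CC2)C[C@H]1OC`, is to be measured in this assay. Relative to compound 3 the change is 1-(dimethylcarbamoyl)piperidin-4-yl in place of 2-(1H-1,2,4-triazol-1-yl)ethyl on a saturated chain carbon bound to an amine nitrogen in a ring. Among the compounds with values here, the step that bears most directly on this is the one from compound 1 to compound 3, a 3.4-fold higher number from compound 1 to compound 3 (0.53 log units; beyond the scatter), where a 1-(ethoxycarbonyl)piperidin-4-yl group on the same saturated chain carbon was exchanged for the 2-(1H-1,2,4-triazol-1-yl)ethyl group; the move to compound 4 runs this exchange in reverse, with a 1-(dimethylcarbamoyl)piperidin-4-yl group closely resembling the 1-(ethoxycarbonyl)piperidin-4-yl group of compound 1. The step from compound 1 to compound 2, a 1.7-fold higher number from compound 1 to compound 2 (0.24 log units; within the scatter), stayed within the scatter, so only the triazole-bearing compound 3 sits clearly apart. The expected step is therefore a 3.2-fold lower number from compound 3 to compound 4 (0.50 log units; beyond the scatter), a modest move toward a lower number, bringing compound 4 near the value of compound 1. Compound 4 is estimated at 400 nM, with a range from 180 nM to 900 nM.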

Compound 4, half-maximal inhibitory concentration: 52 nM
Beside the measured number, compound 4's estimate is 7.7-fold (0.89 log units) above it; the whole stated range lies above it.
By their numbers in this assay, from the lowest: compound 4; then compounds 1, 2 and 3 (each within the scatter of the next, the first and the last beyond it).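

In this assay, within the data shown here, the group on the carbonyl carbon turns out to carry much of the effect, a variable the earlier compounds did not test: dimethylamino in place of ethoxy gives a 7.3-fold lower number from compound 1 to compound 4 (0.86 log units; beyond the scatter) and is the only difference in that pair, so the piperidin-4-yl unit does not alone set the number. Among these compounds, at the saturated chain carbon bound to an amine nitrogen in a ring, 1-(dimethylcarbamoyl)piperidin-4-yl gives steps well beyond any among the earlier compounds, both in place of 2-(1H-1,2,4-triazol-1-yl)ethyl (a 24-fold lower number from compound 3 to compound 4 (1.39 log units; beyond the scatter)) and in place of 2-(1H-pyrrol-1-yl)ethyl (a 12-fold lower number from compound 2 to compound 4 (1.10 log units; beyond the scatter)), leaving compound 4 as the strongest of the four on this read-out. No supporting data bear on why this exchange has so large an effect.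

Going by these compounds, it remains open whether the result is specific to dimethylamino or extends to other groups on the carbonyl carbon, such as methylamino, pyrrolidin-1-yl or a plain methyl. Also unresolved is how a longer chain to the piperidine, or a cyclohexyl ring in place of the piperidine, would behave with the dimethylcarbamoyl group retained.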